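Replacing a carbamate with a fluorinated cycloalkylmethyl group

A few compounds are considered here, and "the series" means these few. Any claim that something is new, unique, unknown or untested is made for them only; others in the source may bear on it.

Compound 3 `CS(=O)(=O)c1cnc(O[C@H]2CC[C@H](OC3CCN(C(=O)Oc4ccccc4)CC3)CC2)cn1` gives 9.6 nM in a functional assay on isolated protein for agonist activity at Glucose-dependent insulinotropic receptor (Homo sapiens), read by HTRF and cAMP accumulation; on this read-out higher numbers stand for an effect only at larger amounts of compound and lower numbers for an effect already at smaller amounts. Among the three measured compounds it holds the second highest number; compound 1 `CC(C)(C)OC(=O)N1CCC(O[C@H]2CC[C@H](Oc3ccc(S(C)(=O)=O)cc3F)CC2)CC1` gives 8.5 nM, and compound 2 `CC(C)OC(=O)N1CCC(O[C@H]2CC[C@H](Oc3cnc(S(C)(=O)=O)cn3)CC2)CC1` gives 13.7 nM, both within the scatter of compound 3. For the measured compounds named here, the one measured step that touches this part of the molecule, a 1.4-fold lower number from compound 2 to compound 3 (0.15 log units; within the scatter), swapped only the group on the carbamate oxygen and left the number within the scatter. Compound 4 `CS(=O)(=O)c1cnc(O[C@H]2CC[C@H](OC3CCN(CC4(C(F)(F)F)CCCC4)CC3)CC2)cn1` goes further: a group of 10 heavy atoms (7 carbon, 3 fluorine; one five-membered non-aromatic ring of carbon only) in place of a group of 9 heavy atoms (7 carbon, 2 oxygen; one six-membered aromatic ring of carbon only), on an amine nitrogen in a ring. Going by the values given here, that removes the carbonyl and its oxygens altogether, a change no measured pair covers, so the expectation for compound 4 rests weakly on the small step from compound 2 to compound 3. Given that the three measured carbamates all sit close together in this assay, compound 4 is expected to give 30 nM, with a range from 8 nM to 120 nM. The step that this estimate means for compound 4 is expected to be a 3.1-fold higher number from compound 3 to compound 4 (0.49 log units; beyond the scatter).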

Compound 4, half-maximal effective concentration: 48.8 nM
Compound 4: middle estimate off by 1.6-fold (0.21 log units), on the low side, and the stated range covers the measured number.
By their numbers in this assay, from the lowest: compounds 1, 3 and 2 (each within the scatter of the next); then compound 4.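

In this assay, the carbamate on the amine nitrogen in a ring proves dispensable for activity: compound 4, whose new group has no carbonyl and no hydrogen-bond acceptors, still gives 48.8 nM. The replacement does carry a cost, which the swap on the carbamate oxygen did not reveal, with a 5.1-fold higher number from compound 3 to compound 4 (0.71 log units; beyond the scatter) and a 3.6-fold higher number from compound 2 to compound 4 (0.55 log units; beyond the scatter). Nothing available here accounts for this loss.

The change alters the carbonyl, the oxygens and the ring all at once, leaving open which of these differences lies behind the step. A cyclopentylmethyl group without the fluorines, or an amide on the same nitrogen, would be needed to show what the trifluoromethyl and the carbonyl each contribute.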